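The source may hold more compounds than are shown below. What is called first, only, known or untested is meant among the compounds shown, and "the series" means these compounds.

Compound 1 `COc1ccccc1NC(=O)c1c(NO)cc(-c2ccccc2)oc1=O` and compound 2 `O=C(Nc1ccc(Cl)cc1)c1c(NO)cc(-c2cccs2)oc1=O` share one core and have been tested in an ADME assay on Huh-7 cells (Homo sapiens) for cytotoxicity, with a stated time of 3 days; on this read-out higher numbers stand for lower toxicity in this test and lower numbers for higher toxicity in this test. Compound 1 gives in this assay only a limit of the assay, > 20000 nM. Compound 2 likewise gives only a limit in this assay, > 20000 nM. Compound 2 therefore stands at the limit of > 20000 nM in this assay, at which 2 of the 2 values shown sit; no number separates it from compound 1, and no order between the two can be read. Compound 3 `Cc1cccc(NC(=O)c2c(NO)cc(-c3cccs3)oc2=O)c1` is not yet measured in this assay. It differs from compound 2 in one place: 3-methylphenyl in place of 4-chlorophenyl on an amide-type nitrogen. Going by the values given here, no measured pair carries this change, so its effect on this assay is unknown from the data. Because compound 2 gives > 20000 nM, a limit, the expected step that the limit leaves unreadable from compound 2 to compound 3 is none beyond the scatter. Compound 3 is thus estimated at 35000 nM, between 12000 nM and 100000 nM, and will most probably again be reported only as a limit.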

Compound 3, half-maximal cytotoxic concentration: > 20000 nM
Compound 3: a limit, no number; the forecaster's own chance of this, stated with the estimate: 85%; the middle value does not contradict the limit.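

No step can be read from compound 2 to compound 3, as both give only a limit in this assay. The compounds shown leave open whether 3-methylphenyl in place of 4-chlorophenyl on an amide-type nitrogen alters cytotoxicity, and at what concentration, if any, compound 1, compound 2 or compound 3 becomes toxic to these cells.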